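Swapping bromo for a substituted phenyl group

The source may report more compounds than this note shows. Statements on the series, on what has been measured and on what is new or still open speak of the compounds shown alone.

Compound 1 `CC[C@@H](Nc1c(C#N)c(-c2ccc(-c3cccc(C)c3)cc2)nc2cnccc12)C(N)=O` gives 3
Compound 2 `CC[C@@H](Nc1c(C#N)c(-c2ccc(-c3ccccc3COC)cc2)nc2cnccc12)C(N)=O` gives 2.6
Compound 3 `CC[C@@H](Nc1c(C#N)c(-c2ccc(Br)cc2)nc2cnccc12)C(N)=O` gives 2.2

In a physicochemical assay for lipophilicity, read by HPLC, at pH 7.5 (on this read-out higher numbers stand for higher lipophilicity and lower numbers for lower lipophilicity), compound 3 stands lowest of the three at 2.2 on these numbers. Compound 4 `CC[C@@H](Nc1c(C#N)c(-c2ccc(-c3ccccc3C(C)C)cc2)nc2cnccc12)C(N)=O` differs from it by 2-isopropylphenyl in place of bromo on an aromatic carbon with 2-isopropylphenyl in place of bromo on an aromatic carbon. Going by the values given here, two measured steps bear on this when read in reverse: a number 0.80 log units lower from compound 1 to compound 3 (beyond the scatter) and a number 0.40 log units lower from compound 2 to compound 3 (beyond the scatter) are both modest and beyond the scatter. Both end at bromo, so a substituted phenyl group in its place should raise the number. The 2-isopropylphenyl group is carbon only, like the 3-methylphenyl of compound 1, so the larger step is the closer guide. The expected change is a number 0.90 log units higher from compound 3 to compound 4 (beyond the scatter) by this estimate. For compound 4 the estimate is 3.1 with an expected range from 2.7 to 3.5 in most repeat measurements.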

Compound 4, distribution coefficient: 3.5
Beside the measured number, compound 4's estimate is 0.40 log units below it; measured number inside the range.
By their numbers in this assay, from the lowest: compound 3; then compound 2; then compound 1; then compound 4.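

In this assay, 2-isopropylphenyl gives the largest step seen so far at this position, a number 1.30 log units higher from compound 3 to compound 4 (beyond the scatter), and puts compound 4 highest of the four. The substituted phenyl groups do not count alike either, with a number 0.90 log units higher from compound 2 to compound 4 (beyond the scatter) and a number 0.50 log units higher from compound 1 to compound 4 (beyond the scatter). Nothing measured here explains these differences. Still open, on these data alone, is how the number would respond to an amine or a carboxylic acid in place of the isopropyl group. A longer carbon chain there is also untested in the compounds shown, so it remains unclear whether the number would keep rising.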